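A few compounds are considered here, and "the series" means these few. Any claim that something is new, unique, unknown or untested is made for them only; others in the source may bear on it.

Measured so far in a functional assay on A549 cells (Homo sapiens) for cytotoxicity, read by MTT assay, with a stated time of 72 h; on this read-out higher numbers stand for weaker inhibition and lower numbers for stronger inhibition:

Compound 1, `CN(C)Cc1ccc2nc(NC(=O)N/N=C/c3cn(Cc4ccccc4)c4ccccc34)sc2c1`: 2900 nM
Compound 2, `CN(C)Cc1ccc2nc(NC(=O)N/N=C/c3cn(Cc4ccc(Cl)cc4)c4ccccc34)sc2c1`: 840 nM
Compound 3, `CCN(CC)Cc1ccc2nc(NC(=O)N/N=C/c3cn(Cc4ccccc4)c4ccccc34)sc2c1`: 3330 nM

The step of a 3.5-fold lower number from compound 1 to compound 2 (0.54 log units; beyond the scatter) belongs to the change (chloro in place of hydrogen on an aromatic carbon). The cores of compound 1 and compound 3 differ by diethylamino in place of dimethylamino on a saturated chain carbon bound to an aromatic carbon, and that step, a 1.1-fold higher number from compound 1 to compound 3 (0.06 log units; within the scatter), is within scatter, so compound 1 and compound 3 cannot be ordered against each other.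

Compound 4, `CCN(CC)Cc1ccc2nc(NC(=O)N/N=C/c3cn(Cc4ccccc4Cl)c4ccccc34)sc2c1`, awaits measurement in this assay. It differs from compound 3 by chloro in place of hydrogen on an aromatic carbon. This is the same kind of change as from compound 1 to compound 2, not the same: there the chloro sits para to a large group, here ortho to a large group. Going by the values given here, the step is expected to be smaller than a 3.5-fold lower number from compound 1 to compound 2 (0.54 log units; beyond the scatter), because only one comparison, a 3.5-fold lower number from compound 1 to compound 2 (0.54 log units; beyond the scatter), supports the change and it concerns a different place. The expected step for compound 4 is a 2.1-fold lower number from compound 3 to compound 4 (0.32 log units; beyond the scatter). Compound 4 is estimated at 1600 nM, between 600 nM and 4000 nM.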

Compound 4, half-maximal inhibitory concentration: 1390 nM
For compound 4 the middle estimate is 1.2-fold (0.06 log units) above the measured one; the measured number falls inside the stated range.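

In this assay, chloro in place of hydrogen on the benzyl group gives a 2.4-fold lower number from compound 3 to compound 4 (0.38 log units; beyond the scatter), and this step stands level with the earlier one on the other core: the same change on two cores in this assay, a 3.5-fold lower number (0.54 log units; beyond the scatter) from compound 1 to compound 2 and a 2.4-fold lower number (0.38 log units; beyond the scatter) from compound 3 to compound 4, 1.4-fold (0.16 log units) apart, within the scatter of two such steps

The change therefore carries from the core of compound 1 to the core of compound 3 in direction and, within scatter, in size. Two pairs do not show how far this extends, and they cannot separate the place of the chloro from the change of amine, as the chloro of compound 4 sits ortho to a large group and that of compound 2 elsewhere.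

On these data alone, the 2-chlorobenzyl group on the core of compound 1 remains open, as does the chloro position of compound 2 on the core of compound 3. Fluoro or methoxy in place of chloro and morpholine in place of the diethylamino group also remain open.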